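From sec-butyl to cyclohexyl on a sulfur

The source may hold more compounds than are shown below. What is called first, only, known or untested is meant among the compounds shown, and "the series" means these compounds.

Compound 1 `CCC(CC)O[C@@H]1C=C(C(=O)O)C[C@H](NCc2ccc(C(C)(C)C)cc2)[C@H]1NC(C)=O` gives > 200000 nM
Compound 2 `CCC(CC)O[C@@H]1C=C(C(=O)O)C[C@H](NCc2ccc(OC(C)C)cc2)[C@H]1NC(C)=O` gives > 200000 nM
Compound 3 `CCC(CC)O[C@@H]1C=C(C(=O)O)C[C@H](NCc2ccc(SC(C)CC)cc2)[C@H]1NC(C)=O` gives > 200000 nM

All three were read in an ADME assay on cells (Fibroblast, Gallus gallus) for cytotoxicity, read by CCK-8 assay, with a stated time of 48 h (on this read-out lower numbers stand for higher toxicity in this test and higher numbers for lower toxicity in this test), and each value is a limit of the assay, not a number. Compound 3 stands with the other two at the limit of > 200000 nM in this assay, at which 3 of the 3 values shown sit. In compound 4 `CCC(CC)O[C@@H]1C=C(C(=O)O)C[C@H](NCc2ccc(SC3CCCCC3)cc2)[C@H]1NC(C)=O` cyclohexyl takes the place of sec-butyl on a sulfur (cyclohexyl in place of sec-butyl on a sulfur). Going by the values given here, three measured steps bear on this change: a step that the two limits leave unreadable from compound 1 to compound 3, a step that the two limits leave unreadable from compound 2 to compound 3 and a step that the two limits leave unreadable from compound 1 to compound 2. None has a readable size, so none gives a direction. The expectation therefore rests on compound 3 at > 200000 nM, itself a limit. The expected step is a number no higher from compound 3 to compound 4 (the limit leaves the size open), with nothing foreseen beyond the scatter. Compound 4 is estimated at 200000 nM, within an expected range from 100000 nM to 300000 nM.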

Compound 4, half-maximal cytotoxic concentration: > 200000 nM
Compound 4: a limit, no number; the forecaster's own chance of this, stated with the estimate: 85%; the middle value sits exactly at the limit.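

Compound 4 gives > 200000 nM, a limit and not a number. Its steps from compound 1, compound 2 and compound 3 cannot be read. The compounds shown leave open which change to the shared core, if any, would give a measurable value in this assay.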